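A few compounds are considered here, and "the series" means these few. Any claim that something is new, unique, unknown or untested is made for them only; others in the source may bear on it.

For the measured compounds named here, in an ADME assay on HOS cells (Homo sapiens) for cytotoxicity, read by luminescence and ATP content, with a stated time of 48 h (a higher number here means that more compound is tolerated, a lower number that less compound is tolerated), compound 3 (`CN(C)CCCc1cnc2c(c1)c(N)c(C(=O)NCc1ccc(F)cc1F)c(=O)n2O`) gives 5000 nM, the lowest of the three numbers so far. Compound 1 (`Nc1c(C(=O)NCc2ccc(F)cc2F)c(=O)n(O)c2ncc(CCCCCCOCc3ccccc3)cc12`) gives 14400 nM, and compound 2 (`Nc1c(C(=O)NCc2ccc(F)cc2F)c(=O)n(O)c2ncc(CCCC3CCCCC3)cc12`) gives 27400 nM. Compound 4 (`CN(C)C(=O)/C=C/c1cnc2c(c1)c(N)c(C(=O)NCc1ccc(F)cc1F)c(=O)n2O`) carries 2-(dimethylcarbamoyl)ethenyl in place of 3-(dimethylamino)propyl on an aromatic carbon. Going by the values given here, no measured step makes this exact change. Among the compounds with values here, two steps bear on it, each putting dimethylamino at the chain end: a 2.9-fold lower number from compound 1 to compound 3 (0.46 log units; beyond the scatter) and a 5.5-fold lower number from compound 2 to compound 3 (0.74 log units; beyond the scatter). Both are modest, while a 1.9-fold higher number from compound 1 to compound 2 (0.28 log units; within the scatter) separates nothing. Within the data shown here, a modest upward step in this assay is therefore expected, although no measured compound carries the entering group. The expected step is a 2.2-fold higher number from compound 3 to compound 4 (0.34 log units; beyond the scatter). For compound 4 the estimated value is 11000 nM, with an expected range of 4000 nM to 30000 nM.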

Compound 4, half-maximal cytotoxic concentration: > 250000 nM
Compound 4: a limit, no number; the forecaster's own chance of this, stated with the estimate: 15%; at least 22-fold (1.35 log units) between middle value and limit.
By their numbers in this assay, from the lowest: compound 3; then compounds 1 and 2 (each within the scatter of the next). At a limit, above all of these: compound 4.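

In this assay compound 4 stands at a limit, not a number: the limit of > 250000 nM in this assay, at which 1 of the 4 values shown sits. This position on the aromatic carbon therefore allows a far larger change than the earlier side-chain swaps showed, with an at least 50-fold higher number from compound 3 to compound 4 (1.69 log units; beyond the scatter) and an at least 9.1-fold higher number from compound 2 to compound 4 (0.96 log units; beyond the scatter). For the compounds shown here, neither step has a true end point, and 2-(dimethylcarbamoyl)ethenyl is the only entering group here to reach the limit.

The compounds shown leave open whether the carbonyl or the chain's carbon-carbon double bond carries this step. A saturated chain ending in the same dimethyl amide, or an ethenyl chain ending in an amine, could separate the two.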